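The compounds below may be only part of what the source reports. "The series", "measured", "known", "first", "only" and "open" are said of these compounds alone.

Of the compounds shown here, two of the same core have been measured in an assay on cells for activation of vitamin D3 receptor (Rattus norvegicus), read by a luciferase reporter, with a stated time of 16 h; on this read-out lower numbers stand for an effect already at smaller amounts and higher numbers for an effect only at larger amounts of compound. Compound 1 `C=C1[C@H](O)CC(=C/C=C/CCC[C@@H](C)CCCC(C)(C)O)C[C@H]1O` gives 50 nM in this assay. Among the measured compounds shown here, compound 2 `C=C1[C@H](O)CC(=C/C=C/C[C@H](C)C[C@@H](C)CCCC(C)(C)O)C[C@H]1O` gives 3 nM, the lower of the two numbers, and the only measured step, a 17-fold lower number from compound 1 to compound 2 (1.22 log units; beyond the scatter), rests on a methyl in place of hydrogen on a saturated chain carbon bound to two saturated chain carbons.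

Compound 3 `C=C1[C@H](O)CC(=C/C=C/C[C@@H](C)C[C@@H](C)CCCC(C)(C)O)C[C@H]1O` is the compound not yet measured. Compared with compound 2, (the two compounds have the same atoms and bonds and differ only in configuration as drawn: 1 of 5 stereo elements differ; a stereocentre at a saturated chain carbon is drawn R in compound 2 and S in compound 3). For the measured compounds named here, no measured step concerns a change of configuration alone; the one step that exists, from compound 1 to compound 2, adds a group rather than inverting a centre, so it does not speak directly to what an inversion does. Going by the values given here, what is known is only that compound 2 itself gives the lower number of the pair, so compound 3 starts from that point without a guide to the direction of its own step.

Compound 3 is therefore estimated at 8 nM in this assay, within a range of 1.5 nM to 60 nM, which corresponds to an expected step of a 2.7-fold higher number from compound 2 to compound 3 (0.43 log units; beyond the scatter), a wide range that allows for either direction.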

Compound 3, half-maximal effective concentration: 90 nM
Compound 3: middle estimate off by 11-fold (1.05 log units), on the low side; the whole stated range lies below it.
By their numbers in this assay, from the lowest: compound 2; then compounds 1 and 3 (each within the scatter of the next).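

Inverting the methyl-bearing chain carbon from R to S gives a 30-fold higher number from compound 2 to compound 3 (1.48 log units; beyond the scatter) in this assay, so the configuration at this carbon matters at least as much here as the presence of the methyl. Set against the compound without the methyl, the methyl drawn S gives a 1.8-fold higher number from compound 1 to compound 3 (0.26 log units; within the scatter), whereas the methyl drawn R gave a 17-fold lower number from compound 1 to compound 2 (1.22 log units; beyond the scatter); the lower number of compound 2 therefore does not come with the methyl as such, but only with the methyl in one of its two configurations. The large step between the two methyl compounds can be assigned to configuration alone, with no other structural change to share it, on the strength of one fact: the fact that compounds 2 and 3 differ only in the configuration as drawn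

As far as these compounds go, whether a larger or different group at this carbon, such as an ethyl or a hydroxyl, would show the same split between R and S remains open. Also open are what inverting the other stereocentre on the chain would do, and why only the R methyl goes with the lower number, which these values alone cannot tell.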